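This account rests on a few compounds, and the source may have more. Where it says the series, first, only, none or still open, it means among the compounds named here.

Compounds with measured values:
compound 1, `COc1cc2c(Oc3ccc(NC(=O)N/N=C/c4ccc([N+](=O)[O-])cc4)cc3F)ccnc2cc1OCCCN1CCCC1`, 470 nM;
compound 2, `COc1ccc(/C=N/NC(=O)Nc2ccc(Oc3ccnc4cc(OCCCN5CCCCC5)c(OC)cc34)c(F)c2)cc1`, 660 nM;
compound 3, `COc1ccc(/C=N/NC(=O)Nc2ccc(Oc3ccnc4cc(OCCCN5CCC(C)CC5)c(OC)cc34)c(F)c2)cc1`, 470 nM.

In a functional assay on MKN-45 cells (Homo sapiens) for cytotoxicity, read by MTT assay, with a stated time of 72 h (a lower number here means a stronger inhibitor, a higher number a weaker inhibitor), compound 3 and compound 1 give the same number at the digits shown, and together they hold the lowest of the three values, while compound 2 sits a small step away, within the scatter. Among the measured compounds shown here, the only single-point step among the measured compounds, a 1.4-fold lower number from compound 2 to compound 3 (0.15 log units; within the scatter), concerns a methyl on a saturated ring carbon and is itself within the scatter.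

Compound 4, `COc1cc2c(Oc3ccc(NC(=O)N/N=C/c4ccc([N+](=O)[O-])cc4)cc3F)ccnc2cc1OCCCN1CCC(C)CC1`, is compound 3 with one change: nitro in place of methoxy on an aromatic carbon. For the measured compounds named here, no measured pair isolates this exchange. The nearest comparison is compound 1, which carries the nitro group but a different saturated amine ring, against compound 2, which carries the methoxy group; their values differ by less than the usual scatter of this assay . Nothing in the measured set therefore points to a step beyond the scatter from compound 3 to compound 4, and the expected step is a 1.1-fold lower number from compound 3 to compound 4 (0.05 log units; within the scatter). For compound 4 the estimated value in this assay is 420 nM, expected to fall between 200 nM and 900 nM.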

Compound 4, half-maximal inhibitory concentration: 420 nM
Beside the measured number, compound 4's estimate shows no gap at the digits printed; low and high end bracket the measured number.
By their numbers in this assay, from the lowest: compounds 4, 1, 3 and 2 (each within the scatter of the next).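

In this assay, nitro in place of methoxy on an aromatic carbon, para to a large group, can now be read directly: the exchange gives a 1.1-fold lower number from compound 3 to compound 4 (0.05 log units; within the scatter), so this position tolerates the move from 4-methoxyphenyl to 4-nitrophenyl without a change beyond the scatter, at least with the 4-methylpiperidin-1-yl ring in place. The same compound also shows the saturated amine ring with the nitro group held fixed, since 4-methylpiperidin-1-yl in place of pyrrolidin-1-yl on the saturated chain carbon gives a 1.1-fold lower number from compound 1 to compound 4 (0.05 log units; within the scatter), again a step inside the scatter. No measurement shown here bears on why either exchange leaves the number where it is.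

Methoxy and nitro are the only two groups seen at this aromatic carbon, so it remains open whether an amine, a carboxylic acid or a bulkier group such as a second phenyl ring would move the number beyond the scatter. Going by these compounds, on the other side of the molecule, it also remains open whether a morpholine ring or a longer chain carrying the saturated amine would do so.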